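Closing a guanidine into a five-membered ring

The source may hold more compounds than are shown below. What is called first, only, known or untested is meant among the compounds shown, and "the series" means these compounds.

Measured compounds in a functional assay on the whole organism for inhibition, with Rattus norvegicus as the target, with a stated time of 2 h, at a dose of 30 mg/kg by the oral route; on this read-out higher numbers stand for more inhibition at the one dose given (going by the name of the read-out) and lower numbers for less inhibition:
- compound 1, `Cc1ccc(C)n1CC(=O)N=C(N)N`: 96%
- compound 2, `CC1C=C[C@@H](C)N1CC(=O)N=C(N)N`: 100%; 100%; 100% (3 entries)
- compound 3, `C/N=C(\N)NC(=O)CN1C(C)C=C[C@H]1C`: 88%

Compound 3 stands lowest of the two single numbers in this assay. Its nearest neighbour is compound 1, and the gap between the two falls within the usual scatter of this kind of measurement, so the two cannot be told apart. Compound 2 contributes three repeated entries rather than one number.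

The unmeasured compound 4, `CC1C=C[C@@H](C)N1CC(=O)NC1=NCCN1`, differs from compound 3 in one place: a group of 5 heavy atoms (3 carbon, 2 nitrogen; one five-membered non-aromatic ring with 2 hetero atoms) in place of a group of 4 heavy atoms (2 carbon, 2 nitrogen; no ring), on an amide-type nitrogen. No step between two measured compounds describes such a change, so there is no shown precedent for its size or direction. All three measured compounds give high inhibition at this dose, leaving little room for an upward move.

Compound 4 is expected to remain in the same high range, with a step of no change at the digits printed from compound 3 to compound 4 (within the scatter) that stays inside the scatter. The estimate for compound 4 is 88%, within 65% to 100%.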

Compound 4, a percentage reported as inhibition, in the whole organism at one dose (the size of the read-out at that dose, not a potency): 35%
The estimate for compound 4 lay 53 percentage points above the measured number; the measured number lies below the stated range.
By their numbers in this assay, from the lowest: compound 4; then compounds 3 and 1 (each within the scatter of the next).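

In this assay the change on the amide-type nitrogen gives a number 53 percentage points lower from compound 3 to compound 4 (beyond the scatter) and so shows that this position does not accept every group, even though the group that enters differs from the one that leaves by little more than a ring and one carbon. For the compounds shown here, the compounds measured earlier gave no step at all and only high numbers, so they could not show that the read-out can fall this far at the one dose given. Nothing at hand bears on why the number falls.

This single change closes a ring and adds a carbon together, and the compounds shown cannot separate those two parts. An open-chain ethyl group on the guanidine, or a six-membered ring holding the same two nitrogens, would be needed to tell whether the ring itself or its size goes with the lower number.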